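Adding a methyl group beside a triazene nitrogen: expected lipophilicity

A few compounds are considered here, and "the series" means these few. Any claim that something is new, unique, unknown or untested is made for them only; others in the source may bear on it.

Compound 1, `CCCN(C)/N=N/c1ccc(C(=O)O)cc1`: in a physicochemical assay for lipophilicity (on this read-out lower numbers stand for lower lipophilicity and higher numbers for higher lipophilicity), compound 1 gives 0.46.
Compound 2, `CCCCN(C)/N=N/c1ccc(C(=O)O)cc1`: in this assay compound 2 gives 0.97.
Compound 3, `CN(C)/N=N/c1ccc(C(N)=O)cc1`: in this assay compound 3 gives 1.2.

Compound 4, `CCN(C)/N=N/c1ccc(C(N)=O)cc1`, has not yet been measured in this assay. It differs from compound 3 by methyl in place of hydrogen on a saturated chain carbon bound to an amine nitrogen. A change of the same kind was made from compound 1 to compound 2, namely (methyl in place of hydrogen on a saturated chain carbon, three bonds along the chain from an amine nitrogen), and there it gave a number 0.51 log units higher from compound 1 to compound 2 (beyond the scatter). The two changes are not the same: in the first the new methyl sits on a carbon bound to the amine nitrogen, in the second on a carbon three bonds along the chain from it. The difference between the core of compound 1 and the core of compound 3 is not broken down here. Compound 3 sits highest of the three measured numbers, though its gap to compound 2 is within the scatter.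

Because the earlier step was a number 0.51 log units higher from compound 1 to compound 2 (beyond the scatter), a step of about a number 0.50 log units higher from compound 3 to compound 4 (beyond the scatter) is expected from compound 3 to compound 4. Compound 4 is therefore estimated at 1.7, most likely between 1.3 and 2.1.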

Compound 4, partition coefficient: 1.7
For compound 4 middle estimate and measured number coincide at the digits printed; low and high end bracket the measured number.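

In this assay the added methyl gave a number 0.50 log units higher from compound 3 to compound 4 (beyond the scatter) and an earlier methyl gave a number 0.51 log units higher from compound 1 to compound 2 (beyond the scatter) in a step of close size, so in these two cases this kind of change carried over from the core of compound 1 to the core of compound 3. Two steps do not make a rule for the series, however, and the methyl sits at a different place in each: on a saturated chain carbon bound to an amine nitrogen in the new step, and three bonds along the chain from it in the earlier one. Nothing given here explains why the two steps are alike in size.

Still open, from the compounds shown here alone, is whether the same methyl gives a step of this size on a core carrying a nitrile or an ester in place of the carboxylic acid or the amide. Also open, going by these compounds, is what happens on a longer chain, such as pentyl or hexyl, on the amine nitrogen.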